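The source may hold more compounds than are shown below. What is called first, only, known or untested is meant among the compounds shown, and "the series" means these compounds.

Measured so far in a functional assay on NALM-6 cells (Homo sapiens); on this read-out lower numbers stand for stronger inhibition and higher numbers for weaker inhibition:
compound 1, `CCCSC[C@H](NC(C)=O)C(=O)CCl` — 6900 nM
compound 2, `CCCCCCCCCCSC[C@H](NC(C)=O)C(=O)CCl` — 4700 nM

In this assay compound 2 gives the lower of the two numbers, but its gap to compound 1 is within the scatter, so the two cannot be told apart on this read-out. For the measured compounds named here, the one step between them, a 1.5-fold lower number from compound 1 to compound 2 (0.17 log units; within the scatter), is the only step so far, and it already concerns the length of the chain on the sulfur.

Compound 3, `CCCCCCCCCCCCCCSC[C@H](NC(C)=O)C(=O)CCl`, is not yet measured. Against compound 2 the difference is butyl in place of hydrogen on a saturated chain carbon, ten or more bonds along the chain from a sulfur. The step from compound 1 to compound 2 bears directly on this, since it extended the same chain by a longer piece than is added here and produced nothing beyond the scatter. A further extension of the chain is therefore expected to give no step beyond the scatter, and the expected change from compound 2 to compound 3 is a 1.2-fold lower number from compound 2 to compound 3 (0.07 log units; within the scatter). For compound 3 the estimate in this assay is 4000 nM, with a range from 1500 nM to 11000 nM.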

Compound 3, half-maximal inhibitory concentration: 8700 nM
Compound 3: the middle estimate sits 2.2-fold (0.34 log units) below what was measured; the range from low to high includes it.
By their numbers in this assay, from the lowest: compounds 2, 1 and 3 (each within the scatter of the next).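

In this assay, butyl in place of hydrogen on a saturated chain carbon, ten or more bonds along the chain from a sulfur, gives a 1.9-fold higher number from compound 2 to compound 3 (0.27 log units; within the scatter) and so produces no change that can be read at this far end of the chain. This step runs in the opposite numerical direction to a 1.5-fold lower number from compound 1 to compound 2 (0.17 log units; within the scatter) but, since both lie within the scatter, the three compounds show no dependence on chain length and the series stays flat across the chains shown, with no optimum to be named. Nothing available gives a reason for this flat behaviour or bears on the result.

Still open, from the compounds shown here alone, is whether a chain on the sulfur that ends in an amine or a carboxylic acid, or one that carries a phenyl ring, would produce a step beyond the scatter where the plain saturated chains do not. The compounds shown also leave open how much the chloromethyl ketone and the acetamide contribute, as both stay the same throughout.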